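Side-chain carbonyl swap from compound 2 to compound 4

A few compounds are considered here, and "the series" means these few. Any claim that something is new, unique, unknown or untested is made for them only; others in the source may bear on it.

In a functional assay on A549 cells (Homo sapiens) for cytotoxicity, read by MTT assay, with a stated time of 72 h (a lower number here means a stronger inhibitor, a higher number a weaker inhibitor), compound 1 `COc1ncc(-c2ccc3nc(NC(=O)N(C)C)nn3c2)cc1NS(=O)(=O)c1ccc(F)cc1` gives 1190 nM, compound 2 `COc1ncc(-c2ccc3nc(NC(=O)NCCN4CCCC4)nn3c2)cc1NS(=O)(=O)c1ccc(F)cc1` gives 960 nM and compound 3 `COc1ncc(-c2ccc3nc(NC(=O)NCCN4CCCCC4)nn3c2)cc1NS(=O)(=O)c1ccc(F)cc1` gives 610 nM. Compound 2 thus lies within the scatter of both other compounds, and the three values set no firm order.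

Compound 4 `COc1ncc(-c2ccc3nc(NC(=O)NCC(=O)N4CCCC4)nn3c2)cc1NS(=O)(=O)c1ccc(F)cc1` is still unmeasured. It differs from compound 2 as follows: (pyrrolidin-1-yl)carbonyl in place of (pyrrolidin-1-yl)methyl on a saturated chain carbon bound to an amide-type nitrogen. In words, (pyrrolidin-1-yl)carbonyl stands in place of (pyrrolidin-1-yl)methyl on a saturated chain carbon bound to an amide-type nitrogen.

Among the measured compounds shown here, no measured step makes this exact change. The nearest evidence comes from the other side-chain changes: a 1.2-fold lower number from compound 1 to compound 2 (0.09 log units; within the scatter), a 2.0-fold lower number from compound 1 to compound 3 (0.29 log units; within the scatter) and a 1.6-fold lower number from compound 2 to compound 3 (0.20 log units; within the scatter). All three stay within the scatter, so no shift beyond the scatter is expected in this assay. For the measured compounds named here, the series holds no measured example of this carbonyl, so the range is kept wide. The expected step is a 1.4-fold higher number from compound 2 to compound 4 (0.13 log units; within the scatter). For compound 4 the estimate is 1300 nM, with an expected range of 550 nM to 3500 nM.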

Compound 4, half-maximal inhibitory concentration: 2190 nM
The estimate for compound 4 lay 1.7-fold (0.23 log units) below the measured number; the range from low to high includes it.
By their numbers in this assay, from the lowest: compounds 3, 2, 1 and 4 (each within the scatter of the next, the first and the last beyond it).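

In this assay, among the compounds shown here, (pyrrolidin-1-yl)carbonyl on a saturated chain carbon bound to an amide-type nitrogen gives the only steps beyond the scatter: a 2.3-fold higher number from compound 2 to compound 4 (0.36 log units; beyond the scatter) and a 3.6-fold higher number from compound 3 to compound 4 (0.56 log units; beyond the scatter), both modest, with the latter also changing the ring from piperidin-1-yl to pyrrolidin-1-yl. Against dimethylamino the side chain stays within the scatter, at a 1.8-fold higher number from compound 1 to compound 4 (0.26 log units; within the scatter), so this position now separates compound 4 from compound 2 and compound 3 but not from compound 1. Nothing available explains the shift seen with the carbonyl.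

Still open, as far as these compounds go, is whether (piperidin-1-yl)carbonyl would follow (pyrrolidin-1-yl)carbonyl at this position. A longer chain carrying the same carbonyl, or a morpholin-4-yl group in place of the pyrrolidin-1-yl ring, also remains untested in the compounds shown.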